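A few compounds are considered here, and "the series" means these few. Any claim that something is new, unique, unknown or untested is made for them only; others in the source may bear on it.

Compound 1 `COc1ccc(/C=C/C(=O)c2ccc(OC)c3c2OC(C)(C)C=C3)cc1OCC=C(C)C`: > 10000 nM (a limit)
Compound 2 `C=CCOc1cc(/C=C/C(=O)c2ccc(OC)c3c2OC(C)(C)C=C3)ccc1OC`: > 20000 nM (a limit)
Compound 3 `CCC(=O)Oc1cc(/C=C/C(=O)c2ccc(OC)c3c2OC(C)(C)C=C3)ccc1OC`: > 10000 nM (a limit)

All three compounds were tested in an ADME assay on L02 cells (Homo sapiens) for cytotoxicity, read by MTT assay (on this read-out higher numbers stand for weaker inhibition and lower numbers for stronger inhibition), and none gave an exact number. Compound 3 sits at the limit of > 10000 nM in this assay, at which 2 of the 3 values shown sit. Compound 2 sits at the limit of > 20000 nM in this assay, at which 1 of the 3 values shown sits.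

Compound 4 `COc1ccc(/C=C/C(=O)c2ccc(OC)c3c2OC(C)(C)C=C3)cc1OC(=O)C1CC1` has cyclopropyl in place of ethyl on a carbonyl carbon, turning propanoyl into cyclopropylcarbonyl: cyclopropyl in place of ethyl on a carbonyl carbon.

The measured steps that bear most closely on this change alter the group on the same oxygen: a step that the two limits leave unreadable from compound 1 to compound 3 and a step that the two limits leave unreadable from compound 2 to compound 3. The remaining one is a step that the two limits leave unreadable from compound 1 to compound 2. None of them has a size that can be carried over, so the expectation rests on the limit of compound 3 alone. In this assay, compound 3 has the limit > 10000 nM.

Weak inhibition is therefore expected to persist, with no shift beyond the scatter. The expected change is a step that the limit leaves unreadable from compound 3 to compound 4. The estimated value for compound 4 is 15000 nM, with an expected range from 8000 nM to 40000 nM.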

Compound 4, half-maximal inhibitory concentration: > 10000 nM
Compound 4 gave a limit, no number; the forecaster's own chance of this, stated with the estimate: 85%; the middle value is on the limit's open side.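

In this assay, among the compounds shown here, compound 1, compound 2, compound 3 and compound 4 all gave limits rather than exact numbers, so no step among them can be read. The compounds shown leave open what exact value each would reach in this assay, and whether changing the group on the oxygen alters it at all.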